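The source may hold more compounds than are shown below. What is called first, only, known or untested is meant among the compounds shown, and "the series" means these compounds.

Measured compounds:
compound 1 `CN(CCCC(=O)O)CCC(Oc1ccc(C(F)(F)F)cc1)c1ccccc1`, 100000 nM
compound 2 `CN(CCC(Oc1ccc(C(F)(F)F)cc1)c1ccc(F)cc1)CC(=O)O`, 251 nM
compound 3 `CN(CCC(Oc1ccc(Cl)c(C(F)(F)F)c1)c1ccccc1)CC(=O)O`, 398 nM

In an assay on CHO cells for inhibition of sodium- and chloride-dependent glycine transporter 1 (Homo sapiens) (on this read-out higher numbers stand for weaker inhibition and lower numbers for stronger inhibition), compound 1 gives 100000 nM, the highest of the three numbers; the gaps to compound 3 at 398 nM and to compound 2 at 251 nM both lie well beyond the scatter. Compounds 2 and 3 carry a carboxymethyl arm on the amine nitrogen, whereas compound 1 carries a 3-carboxypropyl arm, so the length of that arm is the one feature that separates the weak compound from the two stronger ones within this small set.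

Compound 4 `CN(CCC(=O)O)CCC(Oc1ccc(C(F)(F)F)cc1)c1ccccc1` has not been measured. Its difference from compound 1 is carboxy in place of carboxymethyl on a saturated chain carbon, two bonds along the chain from an amine nitrogen. Compound 4 thus sits between compound 1 and the carboxymethyl compounds in arm length. Going by the values given here, no measured step of this kind exists, so the expectation rests only on the values of compounds 1, 2 and 3. For compound 4 a lower number in this assay is expected, by a step of a 5.0-fold lower number from compound 1 to compound 4 (0.70 log units; beyond the scatter), beyond the scatter, though likely not reaching the level of compound 2 or compound 3. Compound 4 is estimated at 20000 nM, within 3000 nM to 100000 nM.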

Compound 4, half-maximal inhibitory concentration: 31600 nM
Compound 4: middle estimate off by 1.6-fold (0.20 log units), on the low side, and the stated range covers the measured number.
By their numbers in this assay, from the lowest: compounds 2 and 3 (each within the scatter of the next); then compound 4; then compound 1.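

In this assay, going by these compounds alone, going from the 3-carboxypropyl arm to the 2-carboxyethyl arm with the rest of the structure unchanged gives a 3.2-fold lower number from compound 1 to compound 4 (0.50 log units; beyond the scatter), the first reading of this change on its own. Arm length alone therefore moves the number at this position, whereas the earlier gaps also carried differences in the ring substituents. No data at hand account for the step.

As far as these compounds go, compounds 2 and 3 differ from compound 4 in more than one place, so the share of their lower numbers that belongs to the carboxymethyl arm stays open, as does the reading of that arm on the core of compound 4. Also open, from the compounds shown here alone, is how a longer chain such as a 4-carboxybutyl arm, or an amide in place of the carboxylic acid, would read on the same amine nitrogen.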